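Swapping a Pyridine Amide for a Phenethyl Amide

A few compounds are considered here, and "the series" means these few. Any claim that something is new, unique, unknown or untested is made for them only; others in the source may bear on it.

Of the compounds shown here, two built on the same core have been measured so far. Compound 1 `Cc1nc(C)c(CN2CCN(C(=O)c3cccnc3)CC2)nc1C` carries a pyridin-3-yl group on its amide carbonyl, while compound 2 `COc1cccc(/C=C/C(=O)N2CCN(Cc3nc(C)c(C)nc3C)CC2)c1OC` carries a longer unsaturated side chain ending in a dimethoxyphenyl group. In a functional assay on ECV-304 cells (Homo sapiens), with stated times of 30 min and 6 h (on this read-out lower numbers stand for an effect already at smaller amounts and higher numbers for an effect only at larger amounts of compound), compound 1 gives 220000 nM, and in this assay compound 2 gives 340000 nM. Both numbers are high, meaning an effect only at large amounts, and the two values sit within the usual scatter of each other, so nothing separates them.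

Compound 3 `Cc1nc(C)c(CN2CCN(C(=O)CCc3ccccc3)CC2)nc1C` has not yet been measured. It differs from compound 1 in one place: phenethyl in place of pyridin-3-yl on a carbonyl carbon. Among the compounds with values here, no step between measured compounds tells how such a swap plays out here, so the expectation rests only on the fact that both known compounds are weak. The step from compound 1 to compound 3 is expected to be small, a 1.1-fold higher number from compound 1 to compound 3 (0.06 log units; within the scatter), in no clear direction and likely within the scatter. Compound 3 is therefore estimated at 250000 nM, with a plausible range from 80000 nM to 800000 nM.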

Compound 3, half-maximal effective concentration: 150000 nM
Beside the measured number, compound 3's estimate is 1.7-fold (0.22 log units) above it; measured number inside the range.
By their numbers in this assay, from the lowest: compounds 3, 1 and 2 (each within the scatter of the next, the first and the last beyond it).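

In this assay, within the data shown here, the swap on this carbonyl carbon gives a 1.5-fold lower number from compound 1 to compound 3 (0.17 log units; within the scatter) and is the first single change that can be read at this position. The two groups differ in make-up: pyridin-3-yl has 6 heavy atoms, including a ring nitrogen that counts as a hydrogen-bond acceptor, while phenethyl has 8 heavy atoms, all carbon, and no such acceptor, yet this difference gives no separation between the two compounds in this read-out. Nothing available bears on why this is the case.

All the groups shown at this place contain an aromatic ring, and it remains open whether a group without one, such as an amine or a carboxylic acid, would bring the number out of this high range. Going by these compounds, it also remains open whether any change at this place can do that, or whether a change elsewhere on the shared core would be needed.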